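The source may hold more compounds than are shown below. What is called first, only, known or untested is meant among the compounds shown, and "the series" means these compounds.

Of the compounds shown here, three built on one shared core have been tested in an ADME assay on HepG2 cells (Homo sapiens) for cytotoxicity, read by luminescence, CellTiter-Glo and ATP content, with a stated time of 72 h; a higher number here means that more compound is needed for the effect, a lower number that less compound is needed. Compound 1 `COc1cccc(CNCCCNc2ccnc3cc(-c4ccc(C(F)(F)F)cc4)ccc23)c1O` gives 2210 nM. Compound 2 `CCC(CC)c1ccc2c(NCCCNCc3cccc(OC)c3O)ccnc2c1` gives 410 nM in this assay, and compound 3 `COc1cccc(CNCCCNc2ccnc3cc(CC4CCCCC4)ccc23)c1O` gives 970 nM in this assay. Compound 3 thus stands second highest of the three numbers: a 2.3-fold lower number from compound 1 to compound 3 (0.36 log units; beyond the scatter), while a 2.4-fold higher number from compound 2 to compound 3 (0.37 log units; beyond the scatter). The remaining pair, a 5.4-fold lower number from compound 1 to compound 2 (0.73 log units; beyond the scatter), is the largest step among the measured compounds.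

The step followed here leads from compound 3 to compound 4 `COc1ccc(-c2ccc3c(NCCCNCc4cccc(OC)c4O)ccnc3c2)cc1`. 4-methoxyphenyl in place of cyclohexylmethyl on an aromatic carbon Compound 1 carries 4-(trifluoromethyl)phenyl on the same aromatic carbon, so compound 1 is the closest guide: there an aromatic group went with a higher number than cyclohexylmethyl, a 2.3-fold lower number from compound 1 to compound 3 (0.36 log units; beyond the scatter). For the measured compounds named here, compound 4 carries a different aromatic group, 4-methoxyphenyl, so a move in the same direction is plausible, but its size is uncertain and no measured pair shows how the two aromatic groups compare with each other. The expectation for compound 4 is therefore a modest rise, a 1.9-fold higher number from compound 3 to compound 4 (0.27 log units; within the scatter). Compound 4 is estimated at 1800 nM in this assay, with a range from 800 nM to 4500 nM.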

Compound 4, half-maximal effective concentration: 1600 nM
Estimate against measurement, compound 4: 1.1-fold (0.05 log units) above, and the stated range covers the measured number.
By their numbers in this assay, from the lowest: compound 2; then compounds 3, 4 and 1 (each within the scatter of the next, the first and the last beyond it).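

In this assay the swap of cyclohexylmethyl for 4-methoxyphenyl on this aromatic carbon gives a 1.6-fold higher number from compound 3 to compound 4 (0.22 log units; within the scatter) and so cannot be read as a real change, which means that an aromatic group here does not always separate from cyclohexylmethyl, as the aromatic group of compound 1 did. For the compounds shown here, the first direct comparison of two aromatic groups at this carbon, methoxy in place of trifluoromethyl, gives a 1.4-fold lower number from compound 1 to compound 4 (0.14 log units; within the scatter) and shows no difference that can be read. Pentan-3-yl, by contrast, stays apart from the aromatic groups: putting 4-methoxyphenyl in its place gives a 3.9-fold higher number from compound 2 to compound 4 (0.59 log units; beyond the scatter) and leaves the pentan-3-yl compound with the lower number, just as the earlier step of a 5.4-fold lower number from compound 1 to compound 2 (0.73 log units; beyond the scatter) did.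

Still open, from the compounds shown here alone, is how a plain phenyl, or a phenyl carrying an amine or a carboxylic acid, would read at this carbon, and whether a longer chain in the linking part of the shared core would shift these numbers. Nothing given here accounts for any of these differences.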